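The compounds below may be only part of what the source reports. "The series", "measured", "known", "first", "only" and "open" are said of these compounds alone.

Compound 1 `Cn1c(/C=C2\SC(=O)N(CC(=O)Nc3cc(C(C)(C)C)on3)C2=O)nc2ccccc21` was tested in a functional assay on PC-3 cells (Homo sapiens) for inhibition, read by MTT assay, with a stated time of 48 h; on this read-out higher numbers stand for weaker inhibition and lower numbers for stronger inhibition. In that assay compound 1 gives > 50000 nM, which is a limit of the assay and not a measured number. Compound 2 `CCn1c(/C=C2\SC(=O)N(CC(=O)N3CCCCC3)C2=O)nc2ccccc21` was run in the same assay. In this assay compound 2 gives > 50000 nM, again a limit rather than a number. Going by the values given here, compound 1 therefore stands at the limit, and the one further value shown sits there too (the limit of > 50000 nM in this assay, at which 2 of the 2 values shown sit); no measured step between the two can be drawn, since neither gives a number to compare.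

Compound 3 `Cn1c(/C=C2\SC(=O)N(CC(=O)N3CCOCC3)C2=O)nc2ccccc21` has not yet been measured. It differs from compound 1 in one place (morpholin-4-yl in place of (5-(tert-butyl)-1,2-oxazol-3-yl)amino on a carbonyl carbon), morpholin-4-yl in place of (5-(tert-butyl)-1,2-oxazol-3-yl)amino on a carbonyl carbon. Among the compounds with values here, with both measured compounds at the limit, no step in this assay is available to size this change. The step from compound 1 to compound 3 is expected to be none beyond the scatter, a number no higher from compound 1 to compound 3 (the limit leaves the size open), with compound 3 most likely staying at the limit. Compound 3 is estimated at 50000 nM, within a range of 20000 nM to 150000 nM.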

Compound 3, half-maximal inhibitory concentration: > 50000 nM
Compound 3: a limit, no number (the forecaster's own chance of this, stated with the estimate: 85%); the middle value sits exactly at the limit.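

Compound 1 and compound 3 both stand at a limit and not at a number, so no step between them can be read: the limit of > 50000 nM in this assay, at which 3 of the 3 values shown sit.

The compounds shown leave open how morpholin-4-yl in place of (5-(tert-butyl)-1,2-oxazol-3-yl)amino changes inhibition in this assay, and which changes to the shared core would bring a value inside the measurable range.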